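The source may report more compounds than this note shows. Statements on the series, on what has been measured and on what is new or still open speak of the compounds shown alone.

Compound 3 `Oc1ccc(-c2cc(-c3ccncc3)nc(-c3ccccc3Cl)c2)cc1` stands lowest of the three numbers shown in an assay on isolated protein for inhibition of DNA topoisomerase 1 (Homo sapiens), with a stated time of 30 min, tested at 100 uM (a higher number here means a stronger effect of the compound at the concentration tested, a lower number a weaker effect), though within the scatter of both others: in that assay compound 3 gives 9.9%. Compound 1 `Oc1ccc(-c2cc(-c3ccccc3)nc(-c3ccccc3Cl)c2)cc1` gives 13.6% and compound 2 `Oc1ccc(-c2cc(-c3ccc(Cl)cc3)nc(-c3cccnc3)c2)cc1` gives 18.8%; neither gap to compound 3 goes beyond the scatter, so no order among the three can be read from these numbers.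

Going by the values given here, the only step between measured compounds that differ in one place, a number 3.7 percentage points lower from compound 1 to compound 3 (within the scatter), comes from pyridin-4-yl in place of phenyl on an aromatic carbon and lies within the scatter.

Compound 4 `Oc1ccc(-c2cc(-c3cccnc3)nc(-c3ccccc3Cl)c2)cc1` differs from compound 3 as follows: pyridin-3-yl in place of pyridin-4-yl on an aromatic carbon. Among the compounds with values here, no measured pair shows this exchange. Compound 2 also carries a pyridin-3-yl group, but it differs from compound 3 in more than one place, so its value and that of compound 3 show only that the two lie within the scatter of each other. Within the data shown here, the one step that bears on compound 3, a number 3.7 percentage points lower from compound 1 to compound 3 (within the scatter), was within the scatter; a step of similar size, in no fixed direction, is expected for a number 2.1 percentage points higher from compound 3 to compound 4 (within the scatter). The estimate for compound 4 in this assay is therefore 12%, with a range from 3% to 22%.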

Compound 4, a percentage reported as inhibition, at one concentration (the size of the read-out at that concentration, not a potency): 0.9%
For compound 4 the middle estimate is 11.1 percentage points above the measured one, outside the stated range (below it).
By their numbers in this assay, from the lowest: compounds 4, 3, 1 and 2 (each within the scatter of the next, the first and the last beyond it).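

Notes on the position next to the ring nitrogen: in this assay, a number 12.7 percentage points lower from compound 1 to compound 4 (beyond the scatter) is the first change at this position to go beyond the scatter, with pyridin-3-yl in place of phenyl. The two pyridine isomers still cannot be told apart, since a number 9 percentage points lower from compound 3 to compound 4 (within the scatter) stays within the scatter. With pyridin-3-yl held in the series, the exchange of 4-chlorophenyl for 2-chlorophenyl at the other aryl position also counts, as a number 17.9 percentage points lower from compound 2 to compound 4 (beyond the scatter) goes beyond the scatter, though no data here explain any of these steps.

The compounds shown leave open how pyridin-2-yl, or a phenyl ring carrying an amine or a carboxylic acid, would read at the position next to the ring nitrogen. Going by these compounds, it also remains open whether the chlorophenyl step holds with phenyl or pyridin-4-yl at that position, or with 3-chlorophenyl as the exchanged group, and all of these readings rest on a single concentration, so none of them gives a potency.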